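From Compound 3 to Compound 4: A Furan Swap

The compounds below may be only part of what the source reports. "The series", "measured", "known", "first", "only" and "open" are said of these compounds alone.

In a functional assay on MDA-MB-231 cells (Homo sapiens) for antiproliferative activity, read by MTT assay, with a stated time of 72 h (on this read-out higher numbers stand for weaker inhibition and lower numbers for stronger inhibition), compound 3 (`CC1=CC[C@H]2[C@H](CC[C@]2(C)O)C(C)(C)[C@@H]1CC[C@H]1[C@]2(C)CC[C@H](OC(=O)c3ccc(C(F)(F)F)cc3F)C(C)(C)O[C@H]2CC[C@@]1(C)O`) gives 36300 nM. That sits level with compound 1 (`CC1=CC[C@H]2[C@H](CC[C@]2(C)O)C(C)(C)[C@@H]1CC[C@H]1[C@]2(C)CC[C@H](OC(=O)NCc3ccccc3)C(C)(C)O[C@H]2CC[C@@]1(C)O`) at 40300 nM, as a 1.1-fold lower number from compound 1 to compound 3 (0.05 log units; within the scatter) shows. Compound 2 (`CC1=CC[C@H]2[C@H](CC[C@]2(C)O)C(C)(C)[C@@H]1CC[C@H]1[C@]2(C)CC[C@H](OC(=O)c3ccc(F)cc3)C(C)(C)O[C@H]2CC[C@@]1(C)O`) gives 11300 nM, which is clearly lower, and a 3.2-fold higher number from compound 2 to compound 3 (0.51 log units; beyond the scatter) separates it from compound 3.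

Compound 4 (`CC1=CC[C@H]2[C@H](CC[C@]2(C)O)C(C)(C)[C@@H]1CC[C@H]1[C@]2(C)CC[C@H](OC(=O)c3ccco3)C(C)(C)O[C@H]2CC[C@@]1(C)O`) keeps the shared core but carries furan-2-yl in place of 2-fluoro-4-(trifluoromethyl)phenyl on a carbonyl carbon.

Among the compounds with values here, no furan compound has been measured yet, so the guidance is indirect. Two measured steps change the group on this carbonyl carbon and reach beyond the scatter: a 3.6-fold lower number from compound 1 to compound 2 (0.55 log units; beyond the scatter) and a 3.2-fold higher number from compound 2 to compound 3 (0.51 log units; beyond the scatter). Both are modest, so a large move seems unlikely in this assay. Compound 3 lies close to the top of the measured values at 36300 nM, which leaves more room for a lower number than a higher one.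

The expected change is small and may stay within the scatter: a 1.8-fold lower number from compound 3 to compound 4 (0.26 log units; within the scatter). For compound 4, the estimated value is 20000 nM, with an expected range from 8000 nM to 50000 nM.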

Compound 4, half-maximal inhibitory concentration: 14000 nM
Compound 4: middle estimate off by 1.4-fold (0.15 log units), on the high side; measured number inside the range.
By their numbers in this assay, from the lowest: compounds 2 and 4 (each within the scatter of the next); then compounds 3 and 1 (each within the scatter of the next).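

In this assay, the furan-2-yl ring on the carbonyl carbon gives a lower number than the larger 2-fluoro-4-(trifluoromethyl)phenyl group (a 2.6-fold lower number from compound 3 to compound 4 (0.41 log units; beyond the scatter)), and also a lower number than the benzylamino group (a 2.9-fold lower number from compound 1 to compound 4 (0.46 log units; beyond the scatter)). Against the 4-fluorophenyl group, however, it makes no difference that can be told apart (a 1.2-fold higher number from compound 2 to compound 4 (0.09 log units; within the scatter)). So a five-membered aromatic ring with 1 hetero atom does as well here as the six-membered aromatic ring of compound 2, although compound 3 shows that a six-membered aromatic ring alone does not secure the lower number.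

Going by these compounds, whether the ring oxygen matters stays open, and a thiophene ring, an unsubstituted phenyl ring or a saturated tetrahydrofuran ring on the same carbonyl carbon would bear on that. No measurement at hand gives a reason for these differences.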